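The source may hold more compounds than are shown below. What is called first, only, known or untested is meant among the compounds shown, and "the series" means these compounds.

Measured in an assay on HEK-293T cells for inhibition of diacylglycerol lipase-alpha (Homo sapiens), read by colorimetric assay; on this read-out higher numbers stand for weaker inhibition and lower numbers for stronger inhibition:
Compound 1 `O=C(CCCCCCc1ccccc1)c1nnc(-c2ccccc2)[nH]1` gives > 10000 nM, which is a limit of the assay.
Compound 2 `CC(=O)c1coc(C(=O)CCCCCCc2ccccc2)n1` gives 123 nM.
Compound 3 `O=C(CCCCCCc1ccccc1)c1nc(C(F)(F)F)co1` gives 214 nM.

Compound 3 stands highest of the two numbers in this assay; its nearest neighbour is compound 2, and the step of a 1.7-fold higher number from compound 2 to compound 3 (0.24 log units; within the scatter) lies within the scatter. Compound 1 sits at the limit of > 10000 nM in this assay, at which 1 of the 3 values shown sits, and so offers no number for comparison.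

Compound 4 `CC(C)(C)C(=O)c1coc(C(=O)CCCCCCc2ccccc2)n1` differs from compound 3 in one place: (tert-butyl)carbonyl in place of trifluoromethyl on an aromatic carbon. Within the data shown here, the only measured step that bears on this position is a 1.7-fold higher number from compound 2 to compound 3 (0.24 log units; within the scatter), in which a trifluoromethyl in place of an acetyl on the same aromatic carbon left the value within the scatter. Compound 4 brings a carbonyl back to that carbon, now carrying a tert-butyl rather than the methyl of the acetyl. From these two compounds no step beyond the scatter is expected in this assay in either direction, with the value of compound 2 as the closer guide.

For compound 4 the expected value in this assay is 150 nM, with a range of 50 nM to 500 nM. The step this estimate implies is a 1.4-fold lower number from compound 3 to compound 4 (0.15 log units; within the scatter).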

Compound 4, half-maximal inhibitory concentration: 479 nM
Compound 4: the middle estimate sits 3.2-fold (0.50 log units) below what was measured; low and high end bracket the measured number.
By their numbers in this assay, from the lowest: compounds 2 and 3 (each within the scatter of the next); then compound 4. At a limit, above all of these: compound 1.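

In this assay, among these compounds, the group on the carbonyl at this aromatic carbon matters: tert-butyl in place of methyl gives a 3.9-fold higher number from compound 2 to compound 4 (0.59 log units; beyond the scatter), the first step at this position beyond the scatter. (tert-Butyl)carbonyl in place of trifluoromethyl gives a 2.2-fold higher number from compound 3 to compound 4 (0.35 log units; beyond the scatter), so a carbonyl at this carbon does not alone keep the number in the range of compound 2. No measurement shown accounts for the higher number of compound 4.

Open, as far as these compounds go, is whether the number climbs gradually between methyl and tert-butyl on the carbonyl, a question that an ethyl or isopropyl group there would address. Also open, from the compounds shown here alone, is how an amide or a carboxylic acid at this aromatic carbon would read against the acetyl of compound 2.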